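Removing the hydroxyl: a pentan-3-yl analogue of compound 2

The compounds below may be only part of what the source reports. "The series", "measured", "known", "first", "only" and "open" are said of these compounds alone.

The two measured compounds share a core and differ only in the group on a nitrogen on an aromatic ring. Compound 1 `CC[C@@H](COC)Nc1nc(C)nc2c1c(C)nn2-c1ccc(OC)cc1C` carries a 1-(methoxymethyl)propyl group there, and in a functional assay on CHO cells for antagonist activity at corticotropin-releasing factor receptor 1 (Homo sapiens), read by cAMP accumulation (a higher number here means a weaker inhibitor, a lower number a stronger inhibitor), compound 1 gives 135 nM. Compound 2 `CCC[C@@H](CO)Nc1nc(C)nc2c1c(C)nn2-c1ccc(OC)cc1C` carries a 1-(hydroxymethyl)butyl group, and in this assay compound 2 gives 574 nM. Among the two numbers compound 2 stands highest, with a 4.3-fold higher number from compound 1 to compound 2 (0.63 log units; beyond the scatter) separating it from compound 1.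

Compound 3 `CCC(CC)Nc1nc(C)nc2c1c(C)nn2-c1ccc(OC)cc1C` is the next step from compound 2: pentan-3-yl in place of 1-(hydroxymethyl)butyl on a nitrogen on an aromatic ring. Among the measured compounds shown here, the only measured step that bears on this change is a 4.3-fold higher number from compound 1 to compound 2 (0.63 log units; beyond the scatter), in which the hydroxyl-bearing chain gave the higher number. For the measured compounds named here, no measured pair shows what removing both donor and acceptor does, so the expectation for compound 3 rests on that single step and on the direction it points. A return toward the lower number of compound 1 is therefore expected, and the step of a 4.8-fold lower number from compound 2 to compound 3 (0.68 log units; beyond the scatter) is estimated to be modest and downward. For compound 3 an estimate of 120 nM is given, within a range of 35 nM to 400 nM.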

Compound 3, inhibition constant: 42 nM
Estimate against measurement, compound 3: 2.9-fold (0.46 log units) above, within the range that was stated.
By their numbers in this assay, from the lowest: compound 3; then compound 1; then compound 2.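

In this assay, pentan-3-yl, with 0 hydrogen-bond donors and 0 hydrogen-bond acceptors, gives the lowest number of the three groups on this nitrogen on an aromatic ring: the change brings a 14-fold lower number from compound 2 to compound 3 (1.14 log units; beyond the scatter) and a 3.2-fold lower number from compound 1 to compound 3 (0.51 log units; beyond the scatter), both printed as beyond the scatter. The earlier pair could rank only two oxygen-bearing chains, whereas this result shows that, among these three compounds, an oxygen in the group is not required for the lowest number, and that 1-(methoxymethyl)propyl and 1-(hydroxymethyl)butyl both stand above the all-carbon group. No measurement shown here accounts for this order.

The step from compound 2 to compound 3 also changes the shape of the chain and removes a defined stereocentre, so the share of the hydroxyl alone remains unresolved. Going by these compounds, it also remains open whether a longer chain such as heptan-4-yl, a cyclopentyl ring or a chain ending in an amine would fall above or below pentan-3-yl in this assay.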